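Swapping a Benzoyl for a Thiophene Sulfonyl on the Core

A few compounds are considered here, and "the series" means these few. Any claim that something is new, unique, unknown or untested is made for them only; others in the source may bear on it.

Of the compounds shown here, three sharing one core have been tested in an ADME assay on HepG2 2.2.15 cells (Homo sapiens) for cytotoxicity; a higher number here means that more compound is tolerated, a lower number that less compound is tolerated. Compound 1 `CC(C)(C)OC(=O)Nc1ncc(C(Oc2ccc3cc(Br)ccc3c2)c2ccc(Cl)cc2)s1` gives a limit rather than a number, namely > 50000 nM. Compound 2 `Clc1ccc(C(Oc2ccc3cc(Br)ccc3c2)c2cnc(NCC3CCCCC3)s2)cc1` is recorded in this assay as "not toxic" (no number reported), without a figure attached. Compound 3 `O=C(Nc1ncc(C(Oc2ccc3cc(Br)ccc3c2)c2ccc(Cl)cc2)s1)c1ccccc1` stands in this assay as "not toxic" (no number reported), again without a figure. Across the three measured compounds there is thus one limit, (the limit of > 50000 nM in this assay, at which 1 of the 3 values shown sits), and two entries with no number at all, so compound 3 cannot be placed on a numerical scale; it simply sits among compounds that showed no measurable toxicity.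

Compound 4 `O=S(=O)(Nc1ncc(C(Oc2ccc3cc(Br)ccc3c2)c2ccc(Cl)cc2)s1)c1cccs1` has not yet been measured. It differs from compound 3 in one place: (thiophen-2-yl)sulfonyl in place of benzoyl on a nitrogen on an aromatic ring. Among the measured compounds shown here, no measured step between two compounds is available to show how such a change moves this assay, so the size of the step can only be guessed. The expectation is that it stays within the usual scatter, with no direction favoured. That expectation rests on compound 3, which shows "not toxic" (no number reported) in this assay. Compound 4 is therefore estimated at 60000 nM in this assay, with a range from 20000 nM to 200000 nM.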

Compound 4, half-maximal cytotoxic concentration: "not toxic" (no number reported)
No number was reported for compound 4; there is nothing to compare the estimate with.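

Among the compounds shown here, compound 3 and compound 4 are both recorded as "not toxic" in this assay, with no figure for either, so no step between them can be read. The compounds shown leave open how much of each compound the cells tolerate before toxicity appears, because the only figure among them is a limit: the limit of > 50000 nM in this assay, at which 1 of the 4 values shown sits.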